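The compounds below may be only part of what the source reports. "The series", "measured", "known", "first", "only" and "open" are said of these compounds alone.

Measured in a physicochemical assay for metabolic stability, read by HPLC, at pH 4.5, tested at 10 uM; a lower number here means that the compound disappears faster, a higher number that the compound lasts longer:
- compound 1 `COc1nc2ccccc2n1C(=O)NCCCCc1ccccc1`: > 2 h
- compound 2 `O=C(NCCCCc1ccccc1)N1C(=O)c2ccccc2C1=O`: > 2 h

Compound 1 gives > 2 h, which is a limit of the assay and not a number. Compound 2 gives > 2 h, which is also a limit. Compound 1 therefore stands at the limit of > 2 h in this assay, at which 2 of the 2 values shown sit.

Compound 3 `Nc1nc2ccccc2n1C(=O)NCCCCc1ccccc1` carries amino in place of methoxy on an aromatic carbon. Going by the values given here, no measured pair shows what this swap does, so no step beyond the usual scatter is expected in this assay. The estimated change is a step that the limit leaves unreadable from compound 1 to compound 3. For compound 3, the expected half-life is 2.5 h, with an estimated range of 1 h to 6 h.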

Compound 3, half-life: 0.717 h
Compound 3: middle estimate off by 3.5-fold (0.54 log units), on the high side; the measured number lies below the stated range.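

In this assay, putting amino in place of methoxy on this aromatic carbon, between two ring nitrogen atoms, gives an at least 2.7-fold lower number from compound 1 to compound 3 (0.44 log units; beyond the scatter). Going by these compounds alone, this shows that the group at this position can change how long the compound lasts, which the earlier compounds could not show. The full size of the step stays unknown, since the value of compound 1 is only a limit: the limit of > 2 h in this assay, at which 2 of the 3 values shown sit.

The compounds shown leave open whether a methyl or dimethylamino group at this place would track with methoxy or with amino. They also leave open whether the swap would act the same way with a shorter chain.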